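Dechlorination of the benzylidene hydrazide in the MCF7 series

The source may hold more compounds than are shown below. What is called first, only, known or untested is meant among the compounds shown, and "the series" means these compounds.

Measured compounds:
compound 1 `COc1ccc(OC)c(/C=C/c2nnc(Nc3ccc(Cl)cc3)o2)c1` > 100000 nM
compound 2 `COc1ccc(OC)c(/C=C/C(=O)N/N=C/c2ccc(Cl)cc2)c1` 32500 nM

In a functional assay on MCF7 cells (Homo sapiens) for antiproliferative activity, read by sulforhodamine B assay, with a stated time of 48 h (a higher number here means a weaker inhibitor of growth, a lower number a stronger inhibitor of growth), compound 1 gives only a limit, > 100000 nM, as noted in the limit of > 100000 nM in this assay, at which 1 of the 2 values shown sits. Among the compounds with values here, compound 2, with 32500 nM, is the only compound with a number in this assay. Compound 3 `COc1ccc(OC)c(/C=C/C(=O)N/N=C/c2ccccc2)c1` differs from compound 2 by hydrogen in place of chloro on an aromatic carbon. Within the data shown here, no measured pair shows this change, so the step is expected to be small, a modest loss of growth inhibition or none beyond the scatter, a 1.4-fold higher number from compound 2 to compound 3 (0.14 log units; within the scatter). Compound 3 is expected to give about 45000 nM in this assay, between 15000 nM and 100000 nM.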

Compound 3, concentration for total growth inhibition: > 100000 nM
Compound 3 gave a limit, no number; the forecaster's own chance of this, stated with the estimate: 25%; middle value at least 2.2-fold (0.34 log units) away from the limit.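

Taking chloro off this aromatic carbon is not a neutral change in this assay: the 4-chlorophenyl to phenyl swap gives an at least 3.0-fold higher number from compound 2 to compound 3 (0.48 log units; beyond the scatter). Within the hydrazide pair, measurable growth inhibition therefore depends on this substituent, and the position is not indifferent to it. The true size of the step stays unknown, as compound 3 gives only a limit, and the series now sits largely at that limit: the limit of > 100000 nM in this assay, at which 2 of the 3 values shown sit.

Going by these compounds, whether chlorine specifically is needed stays open. A fluoro, bromo, methyl or methoxy group on the same carbon could either keep or lose the growth inhibition of compound 2.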